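The source may report more compounds than this note shows. Statements on the series, on what has been measured and on what is new or still open speak of the compounds shown alone.

Three compounds built on the same core, a pyridinyl ketone bearing an allyloxy group and one or two halogens on the other ring, have been tested in a functional assay on HeLa cells (Homo sapiens) for cytotoxicity, read by sulforhodamine B assay, with a stated time of 48 h; on this read-out lower numbers stand for stronger inhibition and higher numbers for weaker inhibition. Within the data shown here, compound 1 `C=CCOc1cc(Br)ccc1C(=O)c1cccnc1` returns only a limit in this assay, > 100000 nM, which marks the edge of what the measurement can report rather than a true number; it is the one value that sits at the limit of > 100000 nM in this assay, at which 1 of the 3 values shown sits. Compound 2 `C=CCOc1ccc(Br)cc1C(=O)c1cccnc1` gives 96000 nM in this assay. Compound 3 `C=CCOc1c(Cl)cc(Cl)cc1C(=O)c1cccnc1` gives 34000 nM in this assay. Compound 4 `O=C(c1cccnc1)c1ccc(Br)cc1O` has not yet been measured. It differs from compound 1 by hydrogen in place of allyl on an oxygen on an aromatic ring. Among the measured compounds shown here, with no measured pair to draw on, the expected step from compound 1 to compound 4 in this assay is an at least 1.2-fold lower number from compound 1 to compound 4 (0.09 log units; that floor lies within the scatter), nothing beyond the usual scatter, and a fresh limit is about as likely as a number. Compound 4 is therefore expected to give about 80000 nM, somewhere between 30000 nM and 200000 nM.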

Compound 4, half-maximal inhibitory concentration: 37000 nM
Compound 4: the middle estimate sits 2.2-fold (0.33 log units) above what was measured, and the stated range covers the measured number.
By their numbers in this assay, from the lowest: compounds 3 and 4 (each within the scatter of the next); then compound 2. At a limit, above all of these: compound 1.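

Swapping allyl for hydrogen on an oxygen on an aromatic ring is the first single change in this set that can be read in this assay, and it gives an at least 2.7-fold lower number from compound 1 to compound 4 (0.43 log units; beyond the scatter). The allyloxy group is therefore not required for compound 4 to give a measurable number, and on this core, allyloxy to hydroxy moves the read-out towards stronger inhibition. Compound 1 stands at a limit, so the step gives only a minimum and its full size remains unknown: the limit of > 100000 nM in this assay, at which 1 of the 4 values shown sits.

As far as these compounds go, it remains open how a methyl group or a longer chain on that oxygen, or an amine in place of the hydroxy group, would compare. From the compounds shown here alone, it is also open whether the same change would have a similar effect with the halogen pattern of compound 2 or compound 3.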